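Bromo for methoxy on a triazole-linked chalcone

A few compounds are considered here, and "the series" means these few. Any claim that something is new, unique, unknown or untested is made for them only; others in the source may bear on it.

Measured compounds:
compound 1 `COc1cc(/C=C/C(=O)c2cccc(-n3cc(-c4ccc(Br)cc4)nn3)c2)ccc1O`: 19100 nM
compound 2 `COc1ccc(/C=C/C(=O)c2cccc(-n3cc(-c4ccc(F)cc4)nn3)c2)cc1O`: 2500 nM
compound 3 `COc1ccc(-c2cn(-c3cccc(C(=O)/C=C/c4ccc(OC)c(O)c4)c3)nn2)cc1`: 6290 nM

In a functional assay on RAW264.7 cells (Mus musculus) for inhibition, with a stated time of 4 days (on this read-out higher numbers stand for weaker inhibition and lower numbers for stronger inhibition), compound 3 stands second highest of the three numbers, with compound 2 as its nearest neighbour and compound 1 furthest away. Within the data shown here, the single step known here, a 2.5-fold higher number from compound 2 to compound 3 (0.40 log units; beyond the scatter), arose from methoxy in place of fluoro on an aromatic carbon. Compound 4 `COc1ccc(/C=C/C(=O)c2cccc(-n3cc(-c4ccc(Br)cc4)nn3)c2)cc1O` is not yet measured; it differs from compound 3 by bromo in place of methoxy on an aromatic carbon.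

The step from compound 2 to compound 3 bears most directly, since a halogen again replaces the methoxy, but in the opposite direction and with bromo rather than fluoro. Compound 1 also carries bromo, yet its other ring differs from compound 4 in the arrangement of methoxy and hydroxy, so its value is only a loose reference. The expected step in this assay is a 1.4-fold lower number from compound 3 to compound 4 (0.15 log units; within the scatter), a modest move towards a lower number, reversing the step from compound 2 to compound 3. Compound 4 is therefore estimated at 4500 nM, within 1500 nM to 14000 nM.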

Compound 4, half-maximal inhibitory concentration: 6570 nM
Compound 4: the middle estimate sits 1.5-fold (0.16 log units) below what was measured; measured number inside the range.
By their numbers in this assay, from the lowest: compound 2; then compounds 3 and 4 (each within the scatter of the next); then compound 1.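

In this assay, the change from 4-methoxyphenyl to 4-bromophenyl gives a 1.0-fold higher number from compound 3 to compound 4 (0.02 log units; within the scatter), so at this place, para to a large group, bromo and methoxy cannot be told apart. Fluoro stands apart from both, with bromo in place of fluoro giving a 2.6-fold higher number from compound 2 to compound 4 (0.42 log units; beyond the scatter), which matches in direction the step already seen for methoxy in place of fluoro. Among these compounds, with bromo held constant, the result also gives a first reading of the other end of the molecule, where 3-hydroxy-4-methoxyphenyl in place of 4-hydroxy-3-methoxyphenyl gives a 2.9-fold lower number from compound 1 to compound 4 (0.46 log units; beyond the scatter).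

On these data alone, how an amine or a carboxylic acid at the same place would compare with these three groups remains open. The compounds shown come with no measurement that explains any of these steps.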